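Swapping methyl for phenyl on a ring nitrogen

The source may report more compounds than this note shows. Statements on the series, on what has been measured and on what is new or still open speak of the compounds shown alone.

Three compounds sharing one core have numbers in a functional assay on U-937 cells (Homo sapiens) for cytotoxicity, read by MTT assay, with a stated time of 24 h; on this read-out lower numbers stand for stronger inhibition and higher numbers for weaker inhibition. Compound 1 `BrCCCOc1c(Br)cc(Br)cc1Oc1ccc(Br)cc1Br` gives 30.3 ug/mL, compound 2 `BrCCCCOc1c(Br)cc(Br)cc1Oc1ccc(Br)cc1Br` gives 29 ug/mL, and compound 3 `CN1CCN(CCCCCOc2c(Br)cc(Br)cc2Oc2ccc(Br)cc2Br)CC1` gives 49.1 ug/mL. Compound 3 therefore stands level with the other two, since a 1.6-fold higher number from compound 1 to compound 3 (0.21 log units; within the scatter) and a 1.7-fold higher number from compound 2 to compound 3 (0.23 log units; within the scatter) both lie within the usual scatter of repeat measurements.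

Compound 4 `Brc1ccc(Oc2cc(Br)cc(Br)c2OCCCCCN2CCN(c3ccccc3)CC2)c(Br)c1` keeps all of compound 3 except for one change: phenyl in place of methyl on an amine nitrogen in a ring. Among the measured compounds shown here, no measured step tests that spot directly, so the evidence is indirect. Putting (4-methylpiperazin-1-yl)methyl in place of bromo on the chain gave only a 1.7-fold higher number from compound 2 to compound 3 (0.23 log units; within the scatter), and the chain step gave a 1.0-fold lower number from compound 1 to compound 2 (0.02 log units; within the scatter). Since these three compounds stay so close in this assay, no step beyond the scatter is expected, in either direction. The expected change is a 1.2-fold lower number from compound 3 to compound 4 (0.09 log units; within the scatter). Compound 4 is estimated at 40 ug/mL, with an expected range from 20 ug/mL to 75 ug/mL.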

Compound 4, half-maximal inhibitory concentration: 42.5 ug/mL
Compound 4: middle estimate off by 1.1-fold (0.03 log units), on the low side, within the range that was stated.
By their numbers in this assay, from the lowest: compounds 2, 1, 4 and 3 (each within the scatter of the next).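

Among the compounds shown here, the swap of phenyl for methyl on an amine nitrogen in a ring is the first change tested directly at this spot, and in this assay it gives a 1.2-fold lower number from compound 3 to compound 4 (0.06 log units; within the scatter) on the scale of this read-out. Compound 3 and compound 4 therefore cannot be told apart, so a whole six-membered aromatic ring of carbon only can stand on this nitrogen with no step beyond the scatter. No measurement available here bears on why the number holds level across this swap.

From the compounds shown here alone, whether other groups on this nitrogen, such as benzyl, acetyl or a chain ending in a carboxylic acid, would also stay level remains open. Also open, going by these compounds, is whether any group at this spot can carry the number beyond the scatter, in either direction.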